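A few compounds are considered here, and "the series" means these few. Any claim that something is new, unique, unknown or untested is made for them only; others in the source may bear on it.

In a functional assay on MIA cells (Homo sapiens) for inhibition, read by MTT assay, with a stated time of 72 h (on this read-out lower numbers stand for stronger inhibition of growth and higher numbers for weaker inhibition of growth), compound 3 `N#C/C(=C\c1ccc(Cl)cc1)C(=O)NCc1ccc(Cl)c(Cl)c1` gives 31000 nM, the lowest of the two numbers shown. Compound 2 `N#C/C(=C\c1ccccc1)C(=O)NCc1ccc(Cl)c(Cl)c1` gives 47000 nM, and the gap, a 1.5-fold lower number from compound 2 to compound 3 (0.18 log units; within the scatter), lies within the scatter. Compound 1 `N#C/C(=C\c1ccco1)C(=O)NCc1ccc(Cl)c(Cl)c1` reaches only the assay limit of > 50000 nM in this assay. Compound 4 `COc1ccc(/C=C(\C#N)C(=O)NCc2ccc(Cl)c(Cl)c2)cc1` differs from compound 3 by methoxy in place of chloro on an aromatic carbon. The other measured steps, an at least 1.0-fold lower number from compound 1 to compound 2 (0.02 log units; that floor lies within the scatter) and an at least 1.6-fold lower number from compound 1 to compound 3 (0.20 log units; that floor lies within the scatter), also concern the group on that chain carbon, and none of the three steps moved beyond the scatter. Going by the values given here, no measured step exchanges chloro for methoxy. For compound 4 the expected step of a 1.2-fold higher number from compound 3 to compound 4 (0.09 log units; within the scatter) is therefore one within the scatter. Compound 4 is thus estimated at 38000 nM, ranging from 15000 nM to 100000 nM.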

Compound 4, concentration for 50% growth inhibition: 79000 nM
Estimate against measurement, compound 4: 2.1-fold (0.32 log units) below, within the range that was stated.
By their numbers in this assay, from the lowest: compounds 3, 2 and 4 (each within the scatter of the next, the first and the last beyond it).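

In this assay, going by these compounds alone, methoxy in place of chloro on the aromatic carbon para to a large group gives the first step beyond the scatter: a 2.5-fold higher number from compound 3 to compound 4 (0.41 log units; beyond the scatter). Set against the unsubstituted phenyl, methoxy stays within the scatter, with a 1.7-fold higher number from compound 2 to compound 4 (0.23 log units; within the scatter), so only the exchange of chloro for methoxy clearly separates two compounds. The step from compound 1 cannot be read because that compound's value is a limit: the limit of > 50000 nM in this assay, at which 1 of the 4 values shown sits.

Going by these compounds, whether an amine or a carboxylic acid on this aromatic carbon would give a number lower than that of compound 3 remains open.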